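Imidazoline Ligands at the Alpha-2C Receptor: Bromo for Propyl

A few compounds are considered here, and "the series" means these few. Any claim that something is new, unique, unknown or untested is made for them only; others in the source may bear on it.

Compounds measured so far:
Compound 1 `C=CCc1ccccc1OCC1=NCCN1` — 70.8 nM
Compound 2 `CCCc1ccccc1OCC1=NCCN1` — 490 nM

In an assay on isolated protein for binding affinity to Alpha-2C adrenergic receptor (Homo sapiens) (on this read-out higher numbers stand for weaker inhibition and lower numbers for stronger inhibition), compound 2 gives 490 nM, the highest of the two numbers; its nearest neighbour is compound 1, with a 6.9-fold higher number from compound 1 to compound 2 (0.84 log units; beyond the scatter). Compound 3 `Brc1ccccc1OCC1=NCCN1` follows from compound 2 by bromo in place of propyl on an aromatic carbon. Within the data shown here, no measured step involves this kind of change; the only known step swaps groups on a saturated chain, so it does not bear on it. Compound 3 is therefore expected near compound 2, with the step of a 3.3-fold lower number from compound 2 to compound 3 (0.51 log units; beyond the scatter) estimated, giving an estimate of 150 nM (30 nM to 800 nM).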

Compound 3, inhibition constant: 398 nM
Estimate against measurement, compound 3: 2.7-fold (0.42 log units) below; low and high end bracket the measured number.
By their numbers in this assay, from the lowest: compound 1; then compounds 3 and 2 (each within the scatter of the next).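

In this assay bromo in place of propyl on the aromatic carbon, one heavy atom for three carbons, gives no readable difference (a 1.2-fold lower number from compound 2 to compound 3 (0.09 log units; within the scatter)). Bromo does not reproduce the number of allyl at this position (a 5.6-fold higher number from compound 1 to compound 3 (0.75 log units; beyond the scatter)), so among these three groups only the allyl of compound 1 stands apart. No evidence at hand accounts for these results. On these data alone, whether a methoxy group, an amine or a longer chain at this position would read like compound 1 or like compounds 2 and 3 remains open.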